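Changing the Ring on the Carbonyl Carbon

The compounds below may be only part of what the source reports. "The series", "measured", "known", "first", "only" and "open" are said of these compounds alone.

Compounds 1, 2 and 3 share one core and differ only in the ring attached to the carbonyl carbon. Compound 1 `COc1ccc(-c2cc3ccccc3nc2/C=C/C(=O)c2ccc(Br)s2)cc1` carries 5-bromothiophen-2-yl there, and in a functional assay on SK-BR-3 cells (Homo sapiens) for antiproliferative activity, read by XTT assay, with a stated time of 72 h (a lower number here means a stronger inhibitor, a higher number a weaker inhibitor), compound 1 gives 520 nM. Compound 2 `COc1ccc(-c2cc3ccccc3nc2/C=C/C(=O)c2cnc(N)nc2C)cc1` carries 2-amino-4-methylpyrimidin-5-yl in that place. For compound 2 the result in this assay is a limit of the assay, > 10000 nM, so only a range and no number is known. Among the measured compounds shown here, the single measured step, an at least 19-fold higher number from compound 1 to compound 2 (1.28 log units; beyond the scatter), shows that this exchange on the carbonyl carbon weakened the inhibitor strongly, and compound 2 stands at the limit of > 10000 nM in this assay, at which 1 of the 2 values shown sits.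

Compound 3 `COc1ccc(-c2cc3ccccc3nc2/C=C/C(=O)c2c[nH]c3ccccc23)cc1` makes a further exchange at the same place: 1H-indol-3-yl in place of 2-amino-4-methylpyrimidin-5-yl on a carbonyl carbon. For the measured compounds named here, no measured step covers this particular change; the only guide is that the step of an at least 19-fold higher number from compound 1 to compound 2 (1.28 log units; beyond the scatter) was large and went to the weaker side, so the ring on the carbonyl carbon clearly matters in this assay. The step expected for compound 3 is an at least 6.6-fold lower number from compound 2 to compound 3 (0.82 log units; beyond the scatter), a return toward stronger inhibition, though its size is uncertain since it starts from a limit. Compound 3 is expected at 1500 nM, with a range from 400 nM to 8000 nM.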

Compound 3, half-maximal inhibitory concentration: 3450 nM
Compound 3: the middle estimate sits 2.3-fold (0.36 log units) below what was measured; measured number inside the range.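

With 1H-indol-3-yl on the carbonyl carbon, the inhibitor returns to a measurable strength in this assay, and an at least 2.8-fold lower number from compound 2 to compound 3 (0.46 log units; beyond the scatter) gives only the smallest possible size of this recovery, as one end of the step is not a number: (the limit of > 10000 nM in this assay, at which 1 of the 3 values shown sits). The comparison with the first ring has a measured value at both ends; it reads a 6.6-fold higher number from compound 1 to compound 3 (0.82 log units; beyond the scatter) and so places compound 3 on the weaker side of compound 1. Among these three compounds, the order therefore runs from compound 1 through compound 3 to compound 2, which shows that this position gives graded differences in strength and not simply an all-or-nothing result.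

The three rings differ from one another in several features at once, so these compounds cannot show which feature sets the order. On these data alone, it remains open, for example, how a plain phenyl ring or a thiophen-2-yl ring without the bromine would compare on the carbonyl carbon, and such a ring would help to separate the part played by the bromine from that of the ring itself.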